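The compounds below may be only part of what the source reports. "The series", "measured", "known", "first", "only" and "open" are said of these compounds alone.

Compound 1, `O=C(NCc1ccc(S(=O)(=O)c2cc(F)cc(F)c2)cc1)c1cc2cnccc2[nH]1`: 82%
Compound 2, `O=C(NCc1ccc(S(=O)(=O)c2cccc(F)c2)cc1)c1cc2cnccc2[nH]1`: 79%
Compound 3, `O=C(NCc1ccc(S(=O)(=O)c2ccccc2)cc1)c1cc2cnccc2[nH]1`: 75%

These three compounds were measured in an ADME assay on microsomes from liver (Homo sapiens) for metabolic stability, read by LC-MS, with a stated time of 30 min, tested at 1 uM; a lower number here means that less of the compound is left, a higher number that more of the compound is left. They share one core and differ only in the fluoro groups on the phenyl that sits on the sulfonyl sulfur. Compound 3 carries no fluoro at all and gives the smallest of the three numbers, yet the steps leading to it, a number 7 percentage points lower from compound 1 to compound 3 (within the scatter) and a number 4 percentage points lower from compound 2 to compound 3 (within the scatter), as well as a number 3 percentage points lower from compound 1 to compound 2 (within the scatter), all lie within the scatter, so the three compounds cannot be told apart on these numbers.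

Compound 4, `Cc1ccccc1S(=O)(=O)c1ccc(CNC(=O)c2cc3cnccc3[nH]2)cc1`, has not yet been measured. It differs from compound 3 by methyl in place of hydrogen on an aromatic carbon. For the measured compounds named here, no measured step adds a methyl; the closest comparisons are the fluoro changes on the same phenyl, and none of them moved the number beyond the scatter. Because a number 7 percentage points lower from compound 1 to compound 3 (within the scatter) was the largest of those and still within the scatter, no step beyond the scatter is expected for compound 4 in this assay, in either direction. Compound 4 is therefore estimated at 72%, in a range from 55% to 85%. This expected result corresponds to a step of a number 3 percentage points lower from compound 3 to compound 4 (within the scatter).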

Compound 4, percent of the compound remaining: 48%
Beside the measured number, compound 4's estimate is 24 percentage points above it; measured number below the stated range.
By their numbers in this assay, from the lowest: compound 4; then compounds 3, 2 and 1 (each within the scatter of the next).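

In this assay the phenyl on the sulfonyl sulfur proves sensitive to a small change: a single methyl on an aromatic carbon, ortho to a large group, gives a number 27 percentage points lower from compound 3 to compound 4 (beyond the scatter) and so moves the number where the fluoro changes on this phenyl did not. The change to 2-methylphenyl from the fluorinated phenyls reads the same way, with a number 31 percentage points lower from compound 2 to compound 4 (beyond the scatter) and a number 34 percentage points lower from compound 1 to compound 4 (beyond the scatter) on the same scale. Nothing measured here accounts for this drop.

The compounds shown leave open whether the drop belongs to methyl itself or to this carbon, since no other group, such as chloro or methoxy, stands there. They also leave open how a methyl on another carbon of this phenyl, or a longer chain such as ethyl on this one, would read.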